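The source may hold more compounds than are shown below. What is called first, only, known or untested is meant among the compounds shown, and "the series" means these compounds.

Compound 2 `CC(C)(C)Cc1c(-c2ccc(Cl)c(Cl)c2)sc(N)c1C(=O)c1ccc(Cl)cc1` and compound 1 `CC(C)(C)Cc1c(-c2ccc(F)cc2)sc(N)c1C(=O)c1ccc(Cl)cc1` share a core and differ only in one aryl group. For the measured compounds named here, in an assay on CHO cells for displacement of a labelled ligand from adenosine receptor A1 (Homo sapiens), read by scintillation counting, tested at 10 uM (a lower number here means less inhibition, a higher number more inhibition at the concentration tested (going by the name of the read-out)), compound 1 gives 1% and compound 2 gives 1%, so compound 2 stands level with its only neighbour, and the step of no change at the digits printed from compound 1 to compound 2 (within the scatter) lies within the scatter. Compound 3 `Cc1noc(C)c1-c1sc(N)c(C(=O)c2ccc(Cl)cc2)c1CC(C)(C)C` is the next change at that same position: 3,5-dimethyl-1,2-oxazol-4-yl in place of 3,4-dichlorophenyl on an aromatic carbon. Going by the values given here, the one measured step swapped two carbon-only rings and moved nothing, but no step on record puts a ring with two hetero atoms there. The expected step of a number 2 percentage points higher from compound 2 to compound 3 (within the scatter) is therefore none beyond the scatter. Compound 3 is estimated at 3%, between 0% and 15%.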

Compound 3, a percentage reported as inhibition, at one concentration (the size of the read-out at that concentration, not a potency): 1%
Beside the measured number, compound 3's estimate is 2 percentage points above it, and the stated range covers the measured number.
By their numbers in this assay, from the lowest: compounds 1, 2 and 3 (each within the scatter of the next).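

In this assay, the swap to a five-membered ring with two hetero atoms gives no change at the digits printed from compound 2 to compound 3 (within the scatter) and, set against the 4-fluorophenyl group, no change at the digits printed from compound 1 to compound 3 (within the scatter) as well. At this position next to the ring sulfur, then, a 3,5-dimethyl-1,2-oxazol-4-yl group, which carries hydrogen-bond acceptors, reads the same as both carbon-only rings. Nothing available explains this flat reading.

Going by these compounds, with no step beyond the scatter, it stays open whether any group here can shift the reading. A carboxylic acid, an amine or a longer alkyl chain at this position remains untested in the compounds shown.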